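This account rests on a few compounds, and the source may have more. Where it says the series, first, only, none or still open, it means among the compounds named here.

Measured compounds:
Compound 1 `O=C(NS(=O)(=O)c1ccc(F)cc1)c1ccc(Nc2nc(NC3(c4ccc(Cl)cc4)CC3)nc(OCC(F)(F)F)n2)cc1`: 100%
Compound 2 `CCS(=O)(=O)NC(=O)c1ccc(Nc2nc(NC3(c4ccc(Cl)cc4)CC3)nc(OCC(F)(F)F)n2)cc1`: 100%
Compound 3 `CNC(=O)NCCS(=O)(=O)NC(=O)c1ccc(Nc2nc(NC3(c4ccc(Cl)cc4)CC3)nc(OCC(F)(F)F)n2)cc1`: 97%

In an ADME assay on microsomes from liver (Homo sapiens) for metabolic stability, with a stated time of 10 min (on this read-out lower numbers stand for a less stable compound and higher numbers for a more stable compound), compound 1 gives 100%, level with compound 2, whose value in this assay is 100%; compound 3, at 97% in this assay, lies within the scatter of both. The unmeasured compound 4 `CS(=O)(=O)NC(=O)c1ccc(Nc2nc(NC3(c4ccc(Cl)cc4)CC3)nc(OCC(F)(F)F)n2)cc1` differs from compound 1 in one place: methyl in place of 4-fluorophenyl on a sulfonyl sulfur. The nearest measured step is no change at the digits printed from compound 1 to compound 2 (within the scatter), and the wider change a number 3 percentage points lower from compound 1 to compound 3 (within the scatter) is also within the scatter; the group on the sulfonyl sulfur has so far left this read-out untouched. Compound 4 is therefore expected to show a number 2 percentage points lower from compound 1 to compound 4 (within the scatter), no shift beyond the scatter. The estimate for compound 4 is 98%, in a range from 88% to 100%.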

Compound 4, percent of the compound remaining: 100%
Compound 4: middle estimate off by 2 percentage points, on the low side, and the stated range covers the measured number.
By their numbers in this assay, from the lowest: compounds 3, 1, 2 and 4 (each within the scatter of the next).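

Methyl on the sulfonyl sulfur has 1 heavy atom, and 4-fluorophenyl has 7. this assay shows no change at the digits printed from compound 1 to compound 4 (within the scatter) and no change at the digits printed from compound 2 to compound 4 (within the scatter) as well as a number 3 percentage points higher from compound 3 to compound 4 (within the scatter). Among the four compounds, then, neither the aromatic ring of 4-fluorophenyl nor any carbon chain beyond methyl is needed to keep this read-out level. No evidence is available that explains this.

On these data alone, a carboxylic acid or a primary amine at the end of a longer chain on the sulfonyl sulfur remains open. So does any replacement of the 2,2,2-trifluoroethoxy group elsewhere on the shared core.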